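Methoxy replacing heptyl on a sulfonamide aryl ring

The source may hold more compounds than are shown below. What is called first, only, known or untested is meant among the compounds shown, and "the series" means these compounds.

Measured compounds:
compound 1 `Cc1ccc(NS(=O)(=O)c2ccc(N3CCNC3=O)cc2)cc1`, 610 nM
compound 2 `CCCCCCCc1ccc(NS(=O)(=O)c2ccc(N3CCNC3=O)cc2)cc1`, > 1000 nM
compound 3 `Cc1ccc(C)c(NS(=O)(=O)c2ccc(N3CCNC3=O)cc2)c1`, 48 nM

Of the compounds shown here, three sharing one core have been measured in a functional assay on MCF7 cells (Homo sapiens) for antiproliferative activity, read by sulforhodamine B assay, with a stated time of 48 h; on this read-out lower numbers stand for stronger inhibition and higher numbers for weaker inhibition. Compound 1 `Cc1ccc(NS(=O)(=O)c2ccc(N3CCNC3=O)cc2)cc1` gives 610 nM. Compound 3 `Cc1ccc(C)c(NS(=O)(=O)c2ccc(N3CCNC3=O)cc2)c1` gives 48 nM, and the step of a 13-fold lower number from compound 1 to compound 3 (1.10 log units; beyond the scatter) is the largest change seen so far. For compound 2 `CCCCCCCc1ccc(NS(=O)(=O)c2ccc(N3CCNC3=O)cc2)cc1` this assay reports only a limit, > 1000 nM; that is the limit of the limit of > 1000 nM in this assay, at which 1 of the 3 values shown sits. Compound 2 thus stands at the weak end of what has been seen, with no number of its own.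

Compound 4 `COc1ccc(NS(=O)(=O)c2ccc(N3CCNC3=O)cc2)cc1` has not yet been measured. It differs from compound 2 by methoxy in place of heptyl on an aromatic carbon. The step that bears on this change is an at least 1.6-fold higher number from compound 1 to compound 2 (0.21 log units; that floor lies within the scatter), where the chain grew from methyl to heptyl; its floor lies within the scatter, so the measured compounds say little about the chain itself. Removing the heptyl returns compound 4 to the size of compound 1, and methoxy is closer in size to methyl than to heptyl. Compound 4 is therefore expected to land near compound 1, at 700 nM, within 250 nM to 2000 nM. The estimated step of an at least 1.4-fold lower number from compound 2 to compound 4 (0.15 log units; that floor lies within the scatter) would be a move back below the limit.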

Compound 4, half-maximal inhibitory concentration: > 1000 nM
Compound 4 ended at the assay's limit; the forecaster's own chance of this, stated with the estimate: 25%; middle value at least 1.4-fold (0.15 log units) away from the limit.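

Replacing heptyl with methoxy did not bring a readable value back, since compound 4, like compound 2, carries only a limit of this assay, so the step between these two cannot be read and both compounds now rest at that same limit: the limit of > 1000 nM in this assay, at which 2 of the 4 values shown sit.

Methoxy in place of methyl gives an at least 1.6-fold higher number from compound 1 to compound 4 (0.21 log units; that floor lies within the scatter), so this position has now taken a small group as well as a long chain without any reading stronger than that of compound 1, although that floor does not separate compound 4 from compound 1. The sharper contrast is with compound 3, where 4-methoxyphenyl in place of 2,5-dimethylphenyl on the sulfonamide nitrogen gives an at least 20-fold higher number from compound 3 to compound 4 (1.31 log units; beyond the scatter), which sets compound 3 further apart and shows that a small group on the aryl ring does not by itself give the strong reading of compound 3.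

As far as these compounds go, how far compound 2 and compound 4 actually lie past the limit remains open, and with it any ranking of heptyl against methoxy. Also open, from the compounds shown here alone, is whether an amine or a hydroxyl at this position would give a readable value, and whether methoxy would be tolerated on the ring pattern of compound 3.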